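The compounds below may be only part of what the source reports. "The series", "measured", "known", "first", "only" and "open" are said of these compounds alone.

In a functional assay on a cell-free system (plasma, Oryctolagus cuniculus) for inhibition, with stated times of 5 min, 1 min and 6 min (a lower number here means a stronger inhibitor, a higher number a weaker inhibitor), compound 1 `CCOC(=O)c1c(C)nc(-c2cccc(C#N)c2)n1OC` gives 9130 nM, and compound 2 `COn1c(-c2cccc(C#N)c2)nc(C)c1C(=O)O` gives 7990 nM, so the two stand level. Among the compounds with values here, the only measured step, a 1.1-fold lower number from compound 1 to compound 2 (0.06 log units; within the scatter), came with hydrogen in place of ethyl. Compound 3 `Cc1nc(-c2cccc(C#N)c2)n(OCc2ccccc2)c1C(=O)O` differs from compound 2 elsewhere: phenyl in place of hydrogen on a saturated chain carbon bound to an oxygen on an aromatic ring. This is phenyl in place of hydrogen on a saturated chain carbon bound to an oxygen on an aromatic ring, so methoxy becomes benzyloxy. Within the data shown here, the measured step lies at another place and therefore offers only weak guidance, and no measurement yet tests this change. The expected step is a 1.6-fold lower number from compound 2 to compound 3 (0.20 log units; within the scatter), an estimated lean towards a lower number, with no move beyond the scatter expected. For compound 3 the estimated value is 5000 nM, with an expected range from 1000 nM to 25000 nM.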

Compound 3, half-maximal inhibitory concentration: 6240 nM
Beside the measured number, compound 3's estimate is 1.2-fold (0.10 log units) below it; low and high end bracket the measured number.
By their numbers in this assay, from the lowest: compounds 3, 2 and 1 (each within the scatter of the next).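

In this assay, the change from methoxy to benzyloxy gives a 1.3-fold lower number from compound 2 to compound 3 (0.11 log units; within the scatter). Within the data shown here, this is the first reading at the saturated chain carbon bound to an oxygen on an aromatic ring, as the earlier step, a 1.1-fold lower number from compound 1 to compound 2 (0.06 log units; within the scatter), lay at another place, and it shows that the phenyl ring, with its six added carbon atoms, leaves the number level with that of compound 2. No measurement at hand bears on why the number stays level here.

The compounds shown leave open whether any group at this place can move the number beyond the scatter, since only hydrogen and phenyl have been compared on that carbon. A longer chain in place of benzyl, or an amine on the phenyl ring, could test this further.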